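The source may report more compounds than this note shows. Statements on the series, on what has been measured and on what is new or still open speak of the compounds shown alone.

Working notes on the series. Compound 1 `CCc1nnn(Cc2cc(C)cc(C)c2)c1CCO` and compound 2 `CCc1nn(CCO)nc1Cc1cc(Cl)cc(Cl)c1` share a core; compound 3 `CCc1nn(CCO)nc1C(OC)c1cc(Cl)cc(Cl)c1` is not yet measured. In an ADME assay on cells (Mus musculus) for cytotoxicity, read by MTT assay (a higher number here means that more compound is tolerated, a lower number that less compound is tolerated), compound 1 reaches only the limit of the assay, > 100000 nM, which is a limit and not a number. In this assay, among the measured compounds shown here, compound 2 gives 84700 nM, the only number in the set. The other value, that of compound 1, sits at the limit (the limit of > 100000 nM in this assay, at which 1 of the 2 values shown sits). Compound 2 therefore stands alone among the measured values. Compound 3 differs from compound 2 by methoxy in place of hydrogen on a saturated chain carbon bound to two aromatic carbons. For the measured compounds named here, no measured pair describes such a change here, so a step of little size, within the scatter, in either direction is expected from compound 2 to compound 3 a 1.1-fold lower number from compound 2 to compound 3 (0.02 log units; within the scatter). Compound 3 is estimated at 80000 nM, with a range from 30000 nM to 200000 nM.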

Compound 3, half-maximal cytotoxic concentration: 95100 nM
The estimate for compound 3 lay 1.2-fold (0.08 log units) below the measured number; the measured number falls inside the stated range.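

In this assay, among the compounds shown here, the one measured step at this position reads a 1.1-fold higher number from compound 2 to compound 3 (0.05 log units; within the scatter). Methoxy in place of hydrogen on a saturated chain carbon bound to two aromatic carbons therefore leaves the half-maximal cytotoxic concentration unchanged within the scatter, an observation that no earlier measured pair could provide for this change. Compound 1 still gives a limit and not a number, and it differs from compound 3 in more than one place, so it adds no comparison: the limit of > 100000 nM in this assay, at which 1 of the 3 values shown sits.

From the compounds shown here alone, whether other groups at this carbon, such as an amine, a carboxylic acid or a longer chain, would also stay within the scatter remains open. Also open, going by these compounds, is whether methoxy at this place would give the same step with the substituents of compound 1.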